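Pyrrolidin-1-yl to 1H-Imidazol-1-yl on Two Cores

This account rests on a few compounds, and the source may have more. Where it says the series, first, only, none or still open, it means among the compounds named here.

Compound 1, `CCOC(=O)N(C)CC#CCN1CCCC1`: in a functional assay on the whole organism for antagonist activity, with Mus musculus as the target (on this read-out higher numbers stand for an effect only at larger amounts of compound and lower numbers for an effect already at smaller amounts), compound 1 gives > 100 mg/kg, which is a limit of the assay and not a number.
Compound 2, `CCOC(=O)N(C)CC#CCn1ccnc1`: in this assay compound 2 gives > 100 mg/kg, again a limit.
Compound 3, `Cn1ccn(CC#CCN2CCCC2)c1=O`: in this assay compound 3 gives > 10 mg/kg, also a limit.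

Every measured compound here sits at a limit: the limit of > 100 mg/kg in this assay, at which 2 of the 3 values shown sit, and (the limit of > 10 mg/kg in this assay, at which 1 of the 3 values shown sits). Compound 1 and compound 2 share one core and differ in a single place, (1H-imidazol-1-yl in place of pyrrolidin-1-yl on a saturated chain carbon bound to a triple-bonded carbon); the step that the two limits leave unreadable from compound 1 to compound 2. Compound 3 carries a different core, and the difference between the two cores is not broken down here.

Compound 4, `Cn1ccn(CC#CCn2ccnc2)c1=O`, has not been measured. It differs from compound 3 by 1H-imidazol-1-yl in place of pyrrolidin-1-yl on a saturated chain carbon bound to a triple-bonded carbon, the same change that separates compound 1 and compound 2. Compound 3 gives only a limit, and the earlier step is not readable, so the expected step that the limit leaves unreadable from compound 3 to compound 4 rests only on the fact that all three measured compounds stopped at a limit. Compound 4 is expected to give about 30 mg/kg in this assay, probably reported as a limit, with an estimated range from 10 mg/kg to 300 mg/kg.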

Compound 4, dose for half-maximal effect: > 100 mg/kg
Compound 4: no number, only a limit; the forecaster's own chance of this, stated with the estimate: 85%; middle value at least 3.3-fold (0.52 log units) away from the limit.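

Compound 3 and compound 4 both stop at a limit of the assay and not at a number, so no step can be read between them. The compounds shown leave open whether 1H-imidazol-1-yl in place of pyrrolidin-1-yl changes the dose needed for an effect in this assay on either core.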